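From cyclopentyl to 1-methylcyclopropyl: one small swap

This account rests on a few compounds, and the source may have more. Where it says the series, first, only, none or still open, it means among the compounds named here.

Measured in a physicochemical assay for solubility, using the shake flask method, in simulated intestinal fluid, measured as kinetic solubility, with a stated time of 20 h, at pH 6.5; on this read-out higher numbers stand for higher solubility and lower numbers for lower solubility:
Compound 1 `FC(F)(F)c1cccc(-c2nc3cnc(Nc4cc(-c5nnn[nH]5)ccn4)cc3[nH]2)c1`: < 5000 nM
Compound 2 `FC(F)(F)c1ccc(Nc2cc3[nH]c(C4CCCC4)nc3cn2)nc1`: 85000 nM

Compound 1 gives < 5000 nM, which is a limit of the assay and not a number. Among the measured compounds shown here, compound 2, at 85000 nM, holds the only actual number so far and is the single reference point for what follows.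

Compound 3 `CC1(c2nc3cnc(Nc4ccc(C(F)(F)F)cn4)cc3[nH]2)CC1` keeps the core of compound 2 but carries 1-methylcyclopropyl in place of cyclopentyl on an aromatic carbon. For the measured compounds named here, no measured pair of compounds yet shows what a swap of this kind does. In this assay the expected change is small and slightly upward, an estimated 1.2-fold higher number from compound 2 to compound 3 (0.07 log units; within the scatter), no more than the usual scatter of repeated measurements. The estimate for compound 3 is 100000 nM, with an expected range from 35000 nM to 250000 nM.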

Compound 3, solubility: 179000 nM
The estimate for compound 3 lay 1.8-fold (0.25 log units) below the measured number, within the range that was stated.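

Among the compounds shown here, until now, no measured pair of compounds showed what a change at this position does. In this assay, placing 1-methylcyclopropyl in place of cyclopentyl on the aromatic carbon between two ring nitrogen atoms gives a 2.1-fold higher number from compound 2 to compound 3 (0.32 log units; beyond the scatter) and so shows that even a modest step can arise here when both groups are carbon-only rings with no hydrogen-bond donors or acceptors. Nothing measured here explains why the number changes.

This single step cannot separate the contribution of the three-membered ring from that of its methyl group. It also leaves open what happens when the same position carries a group of a different kind, such as an amine or a carboxylic acid, or a longer carbon chain.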